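The source may hold more compounds than are shown below. What is called first, only, known or untested is meant among the compounds shown, and "the series" means these compounds.

The two compounds already measured are compound 1 `Cc1c(-c2cc(Cl)cc(Cl)c2)c(C(=O)O)nn1-c1nc(-c2cc(Cl)cc(Cl)c2)c(SC(C)C)s1` and compound 2 `Cc1nn(-c2nc(-c3ccc(Cl)c(Cl)c3)c(SC(C)C)s2)c(C(=O)O)c1-c1cc(C#N)cc(C(F)(F)F)c1`. In a functional assay on BJAB cells (Homo sapiens) for antiproliferative activity, with a stated time of 4 days (on this read-out higher numbers stand for an effect only at larger amounts of compound and lower numbers for an effect already at smaller amounts), compound 1 gives 2000 nM. In this assay compound 2 gives 3600 nM. Compound 1 has the lower of the two numbers, but the gap between it and compound 2 is within the usual scatter of this kind of measurement, so the two cannot be ranked against each other. The two structures also differ in more than one place, so no single step can be read from them.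

The next compound is compound 3 `Cc1c(-c2cc(Cl)cc(Cl)c2)c(C(=O)O)nn1-c1nc(-c2cc(Cl)ccc2F)c(SC(C)C)s1`. It differs from compound 1 in a single place: 5-chloro-2-fluorophenyl in place of 3,5-dichlorophenyl on an aromatic carbon. For the measured compounds named here, no measured pair shows a change of exactly this kind, so nothing in the data sets a direction for it. A step from compound 1 to compound 3 of no more than the scatter is therefore expected, in either direction, as a 1.3-fold higher number from compound 1 to compound 3 (0.10 log units; within the scatter). Compound 3 is thus estimated to give 2500 nM in this assay, with a range from 800 nM to 8000 nM.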

Compound 3, half-maximal effective concentration: 4800 nM
The estimate for compound 3 lay 1.9-fold (0.28 log units) below the measured number; the measured number falls inside the stated range.
By their numbers in this assay, from the lowest: compounds 1, 2 and 3 (each within the scatter of the next, the first and the last beyond it).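

For the compounds shown here, this is the first step that can be read at a single place: on the aromatic carbon next to the ring nitrogen, in this assay, 5-chloro-2-fluorophenyl in place of 3,5-dichlorophenyl gives a 2.4-fold higher number from compound 1 to compound 3 (0.38 log units; beyond the scatter) and so a modest step beyond the usual scatter. The two groups have the same count of heavy atoms, the same six-membered aromatic ring of carbon only and no hydrogen-bond donors or acceptors, so the number at this position can shift even when those counts stay the same. No measurement of any property of these two groups is available to account for the shift.

One swap cannot show which part of the change matters, the fluorine that enters, the chlorine that leaves or the new arrangement of halogens on the phenyl ring. From the compounds shown here alone, it also remains open how this position would respond to a methoxy group or an amine on that phenyl ring, and whether the same swap would give a similar step with a longer chain in place of the isopropylsulfanyl group.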